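A few compounds are considered here, and "the series" means these few. Any claim that something is new, unique, unknown or untested is made for them only; others in the source may bear on it.

Series notes. Compound 1 `CN(C)CCn1c(N)c(-c2nc3ccccc3[nH]2)c2nc(C#N)c(C#N)nc21` carries a 2-(dimethylamino)ethyl chain on its core; in a functional assay on HL-60 cells (Homo sapiens) for antiproliferative activity, read by MTT assay, with a stated time of 48 h (on this read-out lower numbers stand for stronger inhibition and higher numbers for weaker inhibition), compound 1 gives 2220 nM. Compound 2 `CCN(CC)CCn1c(N)c(-c2nc3ccccc3[nH]2)c2nc(C#N)c(C#N)nc21` differs from compound 1 in one place only: diethylamino in place of dimethylamino on a saturated chain carbon, two bonds along the chain from an aromatic nitrogen. In this assay compound 2 gives 1880 nM, and the step of a 1.2-fold lower number from compound 1 to compound 2 (0.07 log units; within the scatter) is small.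

Compound 3 `CN(C)CCCn1c(N)c(-c2nc3ccccc3n2C)c2nc(C#N)c(C#N)nc21` rests on a second core; the difference between the core of compound 1 and the core of compound 3 is not broken down here. In this assay compound 3 gives 2120 nM, which lies within the scatter of both compound 1 and compound 2, so no order among the three can be read.

Compound 4 `CCN(CC)CCCn1c(N)c(-c2nc3ccccc3n2C)c2nc(C#N)c(C#N)nc21` has not been measured. It differs from compound 3 by the same kind of change as compound 2 from compound 1: diethylamino in place of dimethylamino on a saturated chain carbon, three bonds along the chain from an aromatic nitrogen. The place is not identical: in compound 2 the diethylamino sits on a saturated chain carbon two bonds along the chain from an aromatic nitrogen, whereas in compound 4 it sits three bonds along the chain from an aromatic nitrogen.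

The measured step of a 1.2-fold lower number from compound 1 to compound 2 (0.07 log units; within the scatter) stayed within the scatter, so a similar outcome is expected for compound 4 on its own core. Compound 4 is expected to give 1900 nM in this assay, with 1000 nM to 3600 nM as the likely range. For compound 4 this estimate means a step of a 1.1-fold lower number from compound 3 to compound 4 (0.05 log units; within the scatter).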

Compound 4, half-maximal inhibitory concentration: 2810 nM
For compound 4 the middle estimate is 1.5-fold (0.17 log units) below the measured one; the measured number falls inside the stated range.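

In this assay the exchange of dimethylamino for diethylamino, on a saturated chain carbon three bonds along the chain from an aromatic nitrogen, gives a 1.3-fold higher number from compound 3 to compound 4 (0.12 log units; within the scatter) and so leaves no readable difference on this second core. This does not show that the change is without effect in general or that a real effect transfers between cores, since neither step is large enough to be told from repeat scatter and the two pairs differ in both core and chain, one carrying 2-(diethylamino)ethyl and the other 3-(diethylamino)propyl. What can be said is that the two cores give the same outcome for this change within the scatter, with no sign of a dependence on the core: the same change on two cores in this assay, a 1.2-fold lower number (0.07 log units; within the scatter) from compound 1 to compound 2 and a 1.3-fold higher number (0.12 log units; within the scatter) from compound 3 to compound 4, 1.6-fold (0.19 log units) apart, within the scatter of two such steps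

The compounds shown leave open whether a larger terminal group, such as dipropylamino, or a different end group, such as a primary amine or a carboxylic acid, would move the read-out beyond the scatter. They also leave open how a longer chain would read, and how 2-(dimethylamino)ethyl and 3-(dimethylamino)propyl would compare on one and the same core, a comparison that would separate the chain from the rest of the core.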